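Methoxy added to the fused ring of compound 1

The source may report more compounds than this note shows. Statements on the series, on what has been measured and on what is new or still open speak of the compounds shown alone.

Compound 1 `COc1ccc(-c2[nH]c3ccccc3c2/C=C(\C#N)S(=O)(=O)c2ccccc2)cc1` holds the lowest of the three numbers in a functional assay on HOP-62 cells (Homo sapiens) for inhibition, read by sulforhodamine B assay, with a stated time of 48 h (a lower number here means a stronger inhibitor of growth, a higher number a weaker inhibitor of growth), where compound 1 gives 1000 nM. Compound 2 `COc1ccc2[nH]c(-c3ccccc3)c(C=C(C#N)C#N)c2c1` gives 5300 nM and compound 3 `CCOC(=O)C(=Cc1c(-c2ccccc2)[nH]c2ccccc12)C(=O)OCC` gives 5500 nM; both stand higher than compound 1 by more than the usual scatter, yet neither differs from compound 1 in one place only. Compound 4 `COc1ccc(-c2[nH]c3ccc(OC)cc3c2/C=C(\C#N)S(=O)(=O)c2ccccc2)cc1` carries methoxy in place of hydrogen on an aromatic carbon, a methoxy in place of hydrogen on an aromatic carbon of the shared core. Going by the values given here, no measured pair shows this change on its own, so the expected step, a 1.2-fold higher number from compound 1 to compound 4 (0.08 log units; within the scatter), is small, with no direction claimed beyond the scatter. Compound 4 is estimated at 1200 nM in this assay, within a range from 400 nM to 3500 nM.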

Compound 4, concentration for 50% growth inhibition: 3100 nM
For compound 4 the middle estimate is 2.6-fold (0.41 log units) below the measured one; measured number inside the range.
By their numbers in this assay, from the lowest: compound 1; then compounds 4, 2 and 3 (each within the scatter of the next).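

In this assay, this position now has its first direct reading: a 3.1-fold higher number from compound 1 to compound 4 (0.49 log units; beyond the scatter) with methoxy in place of hydrogen on an aromatic carbon of the fused system. Going by these compounds alone, the shared core therefore takes this group at this place with a modest loss of growth inhibition, which no earlier pair could show. Nothing available bears on the reason for this rise.

Open, from the compounds shown here alone, is whether a hydroxyl, an amine or a longer alkoxy chain at this place would stay nearer compound 1. Also open, going by these compounds, is whether methoxy here gives a similar step in the dinitrile and diester series.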